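Compound 3 to compound 4: a propoxy swap at the limit

The compounds below may be only part of what the source reports. "The series", "measured", "known", "first", "only" and "open" are said of these compounds alone.

In an ADME assay on HFF cells (Homo sapiens) for cytotoxicity, with a stated time of 8 days (on this read-out lower numbers stand for higher toxicity in this test and higher numbers for lower toxicity in this test), compound 3 (`CCCCCCSc1nc(N)nc2c1ncn2/C=C1/CC1(CO)CO`) gives > 300000 nM as a limit and not a number. Compound 1 (`CCCCCCCCOc1nc(N)nc2c1ncn2/C=C1/CC1(CO)CO`) likewise gives > 300000 nM as a limit. Compound 2 (`Nc1nc(NC2CC2)c2ncn(/C=C3/CC3(CO)CO)c2n1`) also gives > 300000 nM as a limit. Compound 4 (`CCCOc1nc(N)nc2c1ncn2/C=C1/CC1(CO)CO`) has propoxy in place of hexylsulfanyl on an aromatic carbon. Three measured steps change the group at that carbon: a step that the two limits leave unreadable from compound 1 to compound 3 and a step that the two limits leave unreadable from compound 2 to compound 3 and a step that the two limits leave unreadable from compound 1 to compound 2 give no readable size. A further limit reading is expected for compound 4 because of the limit of > 300000 nM in this assay, at which 3 of the 3 values shown sit, across the series. The expected size of a number no higher from compound 3 to compound 4 (the limit leaves the size open) is none beyond the scatter. Compound 4 is estimated at 300000 nM with an expected range from 150000 nM to 500000 nM in this assay as well.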

Compound 4, half-maximal cytotoxic concentration: > 300000 nM
Compound 4 gave a limit, no number; the forecaster's own chance of this, stated with the estimate: 85%; the middle value sits exactly at the limit.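

In this assay no new step can be read between compound 4 and compound 1, compound 2 or compound 3, because each reading is a limit: the limit of > 300000 nM in this assay, at which 4 of the 4 values shown sit.

The compounds shown leave open whether the group on that aromatic carbon changes this read-out at all.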